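Aryl ether variation and maximal response across the series

This account rests on a few compounds, and the source may have more. Where it says the series, first, only, none or still open, it means among the compounds named here.

Compound 1 `COc1ccc(-c2ccn(CCC(C)C)c(=O)c2C#N)cc1` gives 160% in a functional assay on CHO cells for positive allosteric modulation of metabotropic glutamate receptor 2 (Homo sapiens), read by scintillation counting and GTPgammaS binding, with a stated time of 30 min; on this read-out lower numbers stand for smaller maximal responses and higher numbers for larger maximal responses. Compound 2 `CC(C)CCn1ccc(-c2ccc(Oc3ccccn3)cc2)c(C#N)c1=O` gives 249%, a change of a number 89 percentage points higher from compound 1 to compound 2 (beyond the scatter). Compound 3 `CC(C)CCn1ccc(-c2ccc(Oc3cccnc3)cc2)c(C#N)c1=O` gives 231%, a change of a number 71 percentage points higher from compound 1 to compound 3 (beyond the scatter); against compound 2 the step is a number 18 percentage points lower from compound 2 to compound 3 (beyond the scatter). Compound 3 therefore stands second highest of the three numbers, nearest to compound 2 and far above compound 1.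

Compound 4 `CC(C)CCn1ccc(-c2ccc(Oc3ccncc3)cc2)c(C#N)c1=O` differs from compound 3 by pyridin-4-yl in place of pyridin-3-yl on an oxygen on an aromatic ring. Going by the values given here, the only step that bears directly on moving the nitrogen within the pyridyl ether is the modest one from compound 2 to compound 3; the two large steps from compound 1 concern the exchange of methyl for a pyridyl ring and set the level rather than the direction here. A step of modest size, or none beyond the scatter, is expected in this assay, with a slight lean downward following the pattern of compound 2 to compound 3. The expected step is a number 16 percentage points lower from compound 3 to compound 4 (beyond the scatter). Compound 4 is estimated at 215%, within a range from 180% to 250%.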

Compound 4, largest response reached (Emax), in percent of the reference or control that the assay uses in the metabotropic glutamate receptor 2 assay: 245%
The estimate for compound 4 lay 30 percentage points below the measured number; measured number inside the range.
By their numbers in the metabotropic glutamate receptor 2 assay, from the lowest: compound 1; then compound 3; then compounds 4 and 2 (each within the scatter of the next).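

In the metabotropic glutamate receptor 2 assay, moving the nitrogen does not lower the response in a steady direction: the step is a number 14 percentage points higher from compound 3 to compound 4 (beyond the scatter), and it is a number 4 percentage points lower from compound 2 to compound 4 (within the scatter), so the pyridin-3-yl ether of compound 3 sits lowest of the three pyridyl ethers, while the pyridin-4-yl ether keeps the gain over methyl, at a number 85 percentage points higher from compound 1 to compound 4 (beyond the scatter). In a physicochemical assay for solubility, at pH 4 (on this read-out lower numbers stand for lower solubility and higher numbers for higher solubility), compound 3 gives >= 4000 ug/mL, which is a limit of the assay. In the physicochemical assay, compound 4 gives >= 4000 ug/mL, again a limit.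

The step between these two compounds in the physicochemical assay cannot be read: the limit of >= 4000 ug/mL in the physicochemical assay, at which 2 of the 2 values shown sit.

Open, going by these compounds, is whether an amine or a carboxylic acid on the pyridin-4-yl ring would hold the response in the metabotropic glutamate receptor 2 assay.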